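The compounds below may be only part of what the source reports. "The series", "measured", "known", "first", "only" and "open" are said of these compounds alone.

In a functional assay on CCRF-CEM cells (Homo sapiens) for inhibition (a lower number here means a stronger inhibitor, a higher number a weaker inhibitor), compound 2 `COc1cc(-c2cc(=O)oc3cc(OC)c(OC)c(OC)c23)cc(OC)c1O` gives 62000 nM and stands at the weak end of the three measured compounds, together with compound 1 `COc1cc2oc(=O)cc(-c3ccc(O)cc3)c2c(OC)c1OC` at 47000 nM which lies within the scatter of it. Compound 3 `COc1cc(OC)c2c(-c3ccc(O)c(OC)c3)cc(=O)oc2c1` at 10600 nM has a lower number than compound 2, and that gap lies beyond the scatter.

Compound 4 `COc1cc(OC)c2c(-c3cc(OC)c(O)c(OC)c3)cc(=O)oc2c1` is still unmeasured. Within the data shown here, it follows from compound 2 by a single change, hydrogen in place of methoxy on an aromatic carbon and no measured pair isolates this change. Compound 1 and compound 2 both keep this methoxy. Compound 3 lacks it and gives 10600 nM but that compound also differs from compound 2 elsewhere, so the gap is only a rough guide and not all of it should carry over.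

In this assay the estimated change is a 3.9-fold lower number from compound 2 to compound 4 (0.59 log units; beyond the scatter) toward a stronger inhibitor, and it is expected to lie beyond the scatter. Compound 4 is expected at 16000 nM with a range of 6000 nM to 45000 nM as the estimate.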

Compound 4, half-maximal inhibitory concentration: > 75000 nM
Compound 4: no number, only a limit; the forecaster's own chance of this, stated with the estimate: 5%; at least 4.6-fold (0.67 log units) between middle value and limit.
By their numbers in this assay, from the lowest: compound 3; then compounds 1 and 2 (each within the scatter of the next). At a limit, above all of these: compound 4.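

In this assay, compound 4 gives > 75000 nM, which is a limit of the assay and not a number. At the position on the fused ring system, hydrogen in place of methoxy brings no gain in strength: the step is an at least 1.2-fold higher number from compound 2 to compound 4 (0.08 log units; that floor lies within the scatter), so it gives only a floor, and the true size of the change cannot be read: the limit of > 75000 nM in this assay, at which 1 of the 4 values shown sits. Among these compounds, the step of an at least 7.0-fold higher number from compound 3 to compound 4 (0.84 log units; beyond the scatter) is the first single-change comparison to go beyond the scatter, and it shows that the one extra methoxy on compound 4 costs strength, so the lower number of compound 3 depends on lacking that group, not on lacking the methoxy on the fused ring system.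

The effect of the fused-ring methoxy remains unresolved in any compound that reads below the limit, and with only hydrogen and methoxy compared there, a small amine or a carboxylic acid at that position is an open question. On these data alone, it is also open whether the cost of the extra methoxy seen with compound 3 would hold on a core that keeps the fused-ring methoxy.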